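This account rests on a few compounds, and the source may have more. Where it says the series, first, only, none or still open, it means among the compounds named here.

Compound 1 `c1ccc(-c2cnco2)c(NCC2=NCCN2)c1`: 17.4 nM
Compound 2 `Cc1nc(-c2ccccc2NCC2=NCCN2)cs1`: 4.47 nM

In a functional assay for activation of Alpha-1A adrenergic receptor (Homo sapiens), read by calcium flux (on this read-out lower numbers stand for an effect already at smaller amounts and higher numbers for an effect only at larger amounts of compound), compound 2 gives the lowest of the two numbers, with compound 1 the nearest. Within the data shown here, the one measured step, a 3.9-fold lower number from compound 1 to compound 2 (0.59 log units; beyond the scatter), came with a change of the five-membered ring. Compound 3 `c1ccc(-c2cnoc2)c(NCC2=NCCN2)c1` differs from compound 2 by 1,2-oxazol-4-yl in place of 2-methyl-1,3-thiazol-4-yl on an aromatic carbon. Among the measured compounds shown here, since the entering ring resembles that of compound 1 more than the one in compound 2, a step back toward compound 1 is expected, estimated as a 2.7-fold higher number from compound 2 to compound 3 (0.43 log units; beyond the scatter). Compound 3 is therefore expected to give about 12 nM in this assay, within 4 nM to 40 nM.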

Compound 3, half-maximal effective concentration: 45.7 nM
Compound 3: the middle estimate sits 3.8-fold (0.58 log units) below what was measured; measured number above the stated range.
By their numbers in this assay, from the lowest: compound 2; then compound 1; then compound 3.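

In this assay, this place on the aromatic ring proves more sensitive than the first step suggested: a 10-fold higher number from compound 2 to compound 3 (1.01 log units; beyond the scatter) follows when 1,2-oxazol-4-yl replaces 2-methyl-1,3-thiazol-4-yl. Even between two rings of the same size and hetero atom count the change is not neutral, with a 2.6-fold higher number from compound 1 to compound 3 (0.42 log units; beyond the scatter) on going from 1,3-oxazol-5-yl to 1,2-oxazol-4-yl. No available evidence accounts for these differences. Still open, on these data alone, is whether the methyl group or the thiazole ring itself sets compound 2 apart, and how an aminomethyl group or a carboxylic acid on the five-membered ring would read.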